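The source may hold more compounds than are shown below. What is called first, only, known or untested is meant among the compounds shown, and "the series" means these compounds.

Working notes on the series. Compound 1 `CC(C)/N=c1\c(O)c(O)\c1=N/C/C=C\COc1csc(CN2CCCCC2)c1` gives in a functional assay for antagonist activity at histamine H2 receptor (Cavia porcellus) (on this read-out lower numbers stand for stronger inhibition and higher numbers for weaker inhibition), a value of 0.78 ug/mL. Its companion, compound 2 `N#CCCNc1c(NC/C=C\COc2csc(CN3CCCCC3)c2)c(=O)c1=O`, gives in this assay 0.31 ug/mL. On these two numbers compound 1 stands highest, and the gap to compound 2 lies beyond the usual scatter, so compound 2 is the more potent of the pair on this read-out. The two differ at more than one place, so their gap is not read as a single step.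

Compound 3 `C/N=c1\c(O)c(O)\c1=N/C/C=C\COc1csc(CN2CCCCC2)c1` is the next member to be measured. It differs from compound 1 in one place: methyl in place of isopropyl on a double-bonded nitrogen. Among the measured compounds shown here, no measured pair shows this step, so its size is not known from the data. The expectation for compound 3 is a step of a 1.2-fold lower number from compound 1 to compound 3 (0.08 log units; within the scatter) that stays within the scatter, in either direction. Compound 3 is accordingly estimated in this assay at 0.65 ug/mL, with a range from 0.25 ug/mL to 1.7 ug/mL.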

Compound 3, half-maximal inhibitory concentration: 0.69 ug/mL
The estimate for compound 3 lay 1.1-fold (0.03 log units) below the measured number; measured number inside the range.
By their numbers in this assay, from the lowest: compound 2; then compounds 3 and 1 (each within the scatter of the next).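

In this assay, among the compounds shown here, methyl in place of isopropyl on a double-bonded nitrogen gives a 1.1-fold lower number from compound 1 to compound 3 (0.05 log units; within the scatter), the first step that can be read at a single place. Going from 3 heavy atoms to 1 heavy atom at this position therefore leaves the read-out within the scatter, so isopropyl and methyl cannot be told apart here on these two compounds. No accompanying data bear on this result.

On these data alone, only these two groups on this nitrogen can be compared in single steps, so it remains open whether a longer chain, such as n-hexyl, or a ring, such as benzyl, would stay within the scatter as well. Also open, as far as these compounds go, is how a carboxylic acid or an amine at this place would read in this assay.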